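This account rests on a few compounds, and the source may have more. Where it says the series, first, only, none or still open, it means among the compounds named here.

Of the compounds shown here, three have been measured in a functional assay on MDA-MB-435 cells (Homo sapiens) for cytotoxicity, read by sulforhodamine B assay, with a stated time of 48 h, tested at 0.01 uM; on this read-out lower numbers stand for a stronger effect and higher numbers for a weaker effect at the one concentration tested. Compound 3 `COc1ccc(-c2cc(/C=C/C(=O)c3ccc(N)cc3)[nH]n2)cc1OC` gives 91% in this assay . Compound 1 `COc1cc(-c2cc(/C=C/C(=O)c3ccc(N)cc3)[nH]n2)cc(OC)c1OC` differs from compound 3 by one change, (methoxy in place of hydrogen on an aromatic carbon), and in this assay compound 1 gives 90%; the step of a number 1 percentage points lower from compound 3 to compound 1 (within the scatter) is small. Compound 2 `COc1ccc(C(=O)/C=C/c2cc(-c3cc(OC)c(OC)c(OC)c3)n[nH]2)cc1OC` gives 95% in this assay , and the step of a number 5 percentage points higher from compound 1 to compound 2 (within the scatter) is likewise small. The difference between the cores of compound 2 and compound 3 is not broken down here; their values show only that both lie close together. All three numbers sit within the scatter of one another, so none of them can be set apart from the others.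

Compound 4 `COc1cc(C(=O)/C=C/c2cc(-c3cc(OC)c(OC)c(OC)c3)n[nH]2)cc(OC)c1OC`, not yet measured, is related to compound 2 by methoxy in place of hydrogen on an aromatic carbon, the same change that leads from compound 3 to compound 1, and it sits in the same surroundings: on an aromatic carbon of a six-membered aromatic ring of carbon only, ortho to a methoxy group, meta to a large group and meta to a methoxy group. Because the same change gave a number 1 percentage points lower from compound 3 to compound 1 (within the scatter), compound 4 is expected to give 94% in this assay , with an expected range from 84% to 100%. The step this estimate implies, a number 1 percentage points lower from compound 2 to compound 4 (within the scatter), is expected to stay within the scatter.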

Compound 4, a percentage reported as activity, at one concentration (the size of the read-out at that concentration, not a potency): 99%
Compound 4: middle estimate off by 5 percentage points, on the low side, and the stated range covers the measured number.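

In this assay, methoxy in place of hydrogen on an aromatic carbon, now on the core of compound 2, gives a number 4 percentage points higher from compound 2 to compound 4 (within the scatter). Set beside the earlier case, the two steps do not differ beyond what repeated measurements would allow: the same change on two cores in this assay, a number 1 percentage points lower (within the scatter) from compound 3 to compound 1 and a number 4 percentage points higher (within the scatter) from compound 2 to compound 4, 5 percentage points apart, within the scatter of two such steps. Among the compounds shown here, this shows that the change, carried from one core to the other, produced no step beyond the scatter on either core, but it does not show that the change has the same effect on both, since neither step can be told from no step at all and a shared effect cannot be read from two such small steps.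

The compounds shown leave open whether a different group at this place on the ring, such as a hydroxyl, an ethoxy group or a carboxylic acid, would give a clearly lower number than the methoxy compounds do. For the compounds shown here, they also leave open whether the change would separate the two cores at any other concentration, as the values here come from only the one concentration tested and say nothing about potency.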